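The source may report more compounds than this note shows. Statements on the series, on what has been measured and on what is new or still open speak of the compounds shown alone.

Measured compounds:
compound 1 `COc1cc2nc(N3CCN(C(=O)c4ccc(Br)o4)[C@H]4CCCC[C@H]43)nc(N)c2cc1OC` — 8.5
compound 2 `COc1cc2nc(N3CCN(C(=O)c4ccc(C(C)=O)o4)[C@H]4CCCC[C@H]43)nc(N)c2cc1OC` — 8.13

In a functional assay on spleen for antagonist activity at Alpha-1B adrenergic receptor (Rattus norvegicus) (a lower number here means a less potent compound, a higher number a more potent compound, by a factor of ten per unit of this negative logarithm), compound 1 gives 8.5, and compound 2 gives 8.13. Going by the values given here, compound 2 therefore stands at the lower of the two numbers, with compound 1 its only neighbour; the single measured step, a number 0.37 log units lower from compound 1 to compound 2 (beyond the scatter), is the whole record of change at the ring that sits on the carbonyl carbon.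

Compound 3 `COc1cc2nc(N3CCN(C(=O)c4cccs4)[C@H]4CCCC[C@H]43)nc(N)c2cc1OC` differs from compound 2 by thiophen-2-yl in place of 5-acetylfuran-2-yl on a carbonyl carbon. Among the compounds with values here, the one measured step bears on it only loosely: it swapped one substituent on the furan for another and moved the number modestly, whereas here the substituent is lost altogether and the ring heteroatom changes. Within the data shown here, there is no measured step for either of those changes. Given that both measured compounds sit close together in this assay, compound 3 is expected to stay near that band, and a step of a number 0.17 log units higher from compound 2 to compound 3 (within the scatter) is estimated. For compound 3 the expected value is 8.3, with a range from 7.7 to 8.9.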

Compound 3, negative logarithm of the antagonist equilibrium constant: 8.78
Compound 3: the middle estimate sits 0.48 log units below what was measured; the measured number falls inside the stated range.
By their numbers in this assay, from the lowest: compound 2; then compounds 1 and 3 (each within the scatter of the next).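

In this assay, the step of a number 0.65 log units higher from compound 2 to compound 3 (beyond the scatter) shows that the substituted furan is not required on this carbonyl carbon, since thiophen-2-yl, which carries no substituent, sits clear of the 5-acetylfuran-2-yl compound. The comparison with the bromo compound, a number 0.28 log units higher from compound 1 to compound 3 (within the scatter), shows that two quite different groups at this place cannot be told apart in this read-out, which leaves compound 2 alone at the low end of the three, beyond the scatter from both others. No accompanying measurement speaks to why the acetyl compound falls away from the other two, so the numbers record the size of these changes and nothing of their origin.

In both new steps the ring heteroatom and the substituent change together, so the compounds shown leave open how much of the difference from compound 2 belongs to the loss of acetyl and how much to sulfur replacing oxygen, a question that an unsubstituted furan ring would address directly. Also open, from the compounds shown here alone, is whether the thiophene ring accepts a substituent at all, for instance a bromo group, an acetyl group or an amine.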